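Carboxy on the distal phenyl of compound 1

The source may report more compounds than this note shows. Statements on the series, on what has been measured and on what is new or still open speak of the compounds shown alone.

Compound 1 `Cc1ccccc1-n1nc(C)c2c1NC(=O)[C@H](C)S[C@@H]2c1ccc(-c2ccccc2)cc1` gives the lowest number of the three measured in an assay on isolated protein for agonist activity at Bile acid receptor (Homo sapiens), read by AlphaScreen, with a stated time of 30 min (a lower number here means that less compound is needed, a higher number that more compound is needed for the effect), at 990 nM. Compound 2 `COc1cc([C@H]2S[C@@H](C)C(=O)Nc3c2c(C)nn3-c2ccccc2C)ccc1Oc1ccccc1` gives 1900 nM in this assay, which lies within the scatter of compound 1. Compound 3 `Cc1nn(-c2ccccc2F)c2c1C(c1ccc(Oc3ccccc3)cc1)SC(C)C(=O)N2` gives 3900 nM in this assay, beyond the scatter of compound 1. Compound 4 `Cc1ccccc1-n1nc(C)c2c1NC(=O)[C@H](C)S[C@@H]2c1ccc(-c2cccc(C(=O)O)c2)cc1` is not yet measured. It differs from compound 1 by carboxy in place of hydrogen on an aromatic carbon, on the six-membered aromatic ring of carbon only, meta to a large group. For the measured compounds named here, no measured pair shows this change, so the direction rests on nothing measured. Expected from compound 1: a small to moderate gain, a step of a 1.7-fold lower number from compound 1 to compound 4 (0.22 log units; within the scatter), with the chance of no change beyond the scatter. For compound 4 the estimate in this assay is 600 nM, within 150 nM to 2500 nM.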

Compound 4, half-maximal effective concentration: "not active" (no number reported)
No number was reported for compound 4, so the estimate cannot be set against anything.
By their numbers in this assay, from the lowest: compounds 1 and 2 (each within the scatter of the next); then compound 3.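

In this assay, for the compounds shown here, compound 4 is reported as not active, without a number, so no step from compound 1 to it can be read. The compounds shown leave open whether any other group in that place on the distal phenyl gives a number. No measured property bears on this result.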